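The source may hold more compounds than are shown below. What is called first, only, known or untested is meant among the compounds shown, and "the series" means these compounds.

Working notes on the series. Among the compounds with values here, the two measured members share a core that carries a dithiocarbamate-linked methyl arm. Compound 1, `COc1ccc2oc(CSC(=S)N3CCOCC3)cc(=O)c2c1`, bears a methoxy group and a morpholine on the thiocarbonyl carbon; in a functional assay on SW480 cells (Homo sapiens) for antiproliferative activity, read by MTT assay, with a stated time of 72 h (a higher number here means a weaker inhibitor, a lower number a stronger inhibitor), compound 1 gives 3100 nM. Compound 2, `O=c1cc(CSC(=S)N2CCCCC2)oc2cc(Cl)ccc12`, carries a chlorine on the core and a piperidine on the thiocarbonyl carbon; in this assay compound 2 gives 2500 nM. Compound 2 sits alongside compound 1 in this assay: the two numbers lie within the scatter of each other, so no ranking between them can be read.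

The next member, compound 3, `O=c1cc(CSC(=S)N2CCCC2)oc2cc(Cl)ccc12`, keeps the chloro core and changes only the amine on the thiocarbonyl carbon: pyrrolidin-1-yl in place of piperidin-1-yl on a thiocarbonyl carbon. Within the data shown here, no measured pair isolates this kind of change, so there is nothing to lean on beyond compound 2 itself. The expectation is a step of no change at the digits printed from compound 2 to compound 3 (within the scatter) in this assay, that is, none clearly beyond the scatter in either direction. Compound 3 is therefore estimated at 2500 nM, with a range of 1000 nM to 6500 nM.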

Compound 3, half-maximal inhibitory concentration: > 25000 nM
Compound 3 ended at the assay's limit; the forecaster's own chance of this, stated with the estimate: 5%; middle value at least 10-fold (1.00 log units) from the limit.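

Compound 3 shows that the amine on a thiocarbonyl carbon is a sensitive point on the chloro core: pyrrolidin-1-yl in place of piperidin-1-yl, a five-membered ring for a six-membered one, gives an at least 10-fold higher number from compound 2 to compound 3 (1.00 log units; beyond the scatter) in this assay. Compound 1 and compound 2 differ in more than one place, so they could not speak to this position alone, whereas this pair changes the amine and nothing else. In this assay compound 3 stands at > 25000 nM, which is a limit of the assay and not a number, so the step has a lower bound but no full size: the limit of > 25000 nM in this assay, at which 1 of the 3 values shown sits.

The compounds shown leave open whether the same step would appear on the methoxy core, with pyrrolidin-1-yl paired against piperidin-1-yl there, since a single pair on one core cannot show a general pattern. They also leave open how a seven-membered azepane ring, an open-chain diethylamino group or a piperazine would behave on the same thiocarbonyl carbon, and so whether the six-membered ring is itself special or only one tolerated amine among several.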